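The compounds below may be only part of what the source reports. "The series", "measured", "known", "first", "only" and "open" are said of these compounds alone.

Compounds measured so far in a functional assay on KYSE-410 cells (Homo sapiens) for antiproliferative activity, read by MTT assay, with a stated time of 72 h; a lower number here means a stronger inhibitor, a higher number a weaker inhibitor
- Compound 1 `CC(C)(C)c1ccc(-c2ccc3c(C(=O)Nc4cccc(F)c4)cc(=O)[nH]c3c2)cc1` gives > 20000 nM as a limit of the assay, not a number
- Compound 2 `O=C(Nc1cccc(F)c1)c1cc(=O)[nH]c2cc(-c3ccc(F)cc3)ccc12` gives 10300 nM
- Compound 3 `O=C(Nc1cccc(F)c1)c1cc(=O)[nH]c2cc(-c3ccsc3)ccc12` gives 4300 nM

Compound 3 stands lowest of the three, with the gap to compound 1 only a minimum (an at least 4.6-fold lower number from compound 1 to compound 3 (0.66 log units; beyond the scatter)). Compound 4 `O=C(Nc1cccc(F)c1)c1cc(=O)[nH]c2cc(-c3cccc(F)c3)ccc12` has not been measured. It carries 3-fluorophenyl in place of thiophen-3-yl on an aromatic carbon of the shared core (3-fluorophenyl in place of thiophen-3-yl on an aromatic carbon). The closest guide is compound 2, which also holds a fluorophenyl group at that place and sits higher (a 2.4-fold lower number from compound 2 to compound 3 (0.38 log units; beyond the scatter)). A modest rise of similar size is therefore expected (a 2.0-fold higher number from compound 3 to compound 4 (0.30 log units; within the scatter)). For compound 4 the estimated value is 8500 nM (expected range 3800 nM to 19000 nM).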

Compound 4, half-maximal inhibitory concentration: 10900 nM
Estimate against measurement, compound 4: 1.3-fold (0.11 log units) below; the measured number falls inside the stated range.
By their numbers in this assay, from the lowest: compound 3; then compounds 2 and 4 (each within the scatter of the next). At a limit, above all of these: compound 1.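

With 3-fluorophenyl in place of 4-fluorophenyl, the number does not shift beyond the scatter (a 1.1-fold higher number from compound 2 to compound 4 (0.02 log units; within the scatter)), so at this position the two fluorophenyl groups cannot be told apart. Thiophen-3-yl now stands ahead of a second fluorophenyl group (a 2.5-fold higher number from compound 3 to compound 4 (0.40 log units; beyond the scatter)), so its lead does not rest on compound 2 alone. The step from compound 1 cannot be read as a size, since compound 1 gives a limit and only a floor is known (an at least 1.8-fold lower number from compound 1 to compound 4 (0.26 log units; that floor lies within the scatter)).

Open, from the compounds shown here alone, is whether the lead extends to other five-membered rings, such as furan-3-yl or thiophen-2-yl. Also open, going by these compounds, is how unsubstituted phenyl, or a phenyl carrying an amine, would compare.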